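A few compounds are considered here, and "the series" means these few. Any claim that something is new, unique, unknown or untested is made for them only; others in the source may bear on it.

Measured compounds in an assay on U2OS cells for inhibition of secreted frizzled-related protein 1 (Homo sapiens), read by a luciferase reporter, with a stated time of 18 h; a lower number here means that less compound is needed, a higher number that more compound is needed for the effect:
- compound 1 `O=C(c1cccnc1)N1CCC(NS(=O)(=O)c2cc(S(=O)(=O)c3ccccc3)ccc2C(F)(F)F)CC1`: 120 nM
- compound 2 `O=C(c1ccc(Cl)nc1)N1CCC(NS(=O)(=O)c2cc(S(=O)(=O)c3ccccc3)ccc2C(F)(F)F)CC1`: 140 nM
- compound 3 `O=S(=O)(NC1CCN(S(=O)(=O)c2cccc(-c3nnn[nH]3)c2)CC1)c1cc(S(=O)(=O)c2ccccc2)ccc1C(F)(F)F`: 1200 nM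

Compound 2 stands second highest of the three numbers. Its nearest neighbour is compound 1, where a 1.2-fold higher number from compound 1 to compound 2 (0.07 log units; within the scatter); that step stays within the scatter. Compound 3 is the furthest away: it carries a sulfonyl-linked aryl with a tetrazole on the piperidine nitrogen and gives a clearly higher number than compound 2.

The next compound, compound 4 `O=C(O)c1ccc(N2CCC(NS(=O)(=O)c3cc(S(=O)(=O)c4ccccc4)ccc3C(F)(F)F)CC2)cc1`, changes that same nitrogen: 4-carboxyphenyl in place of (6-chloropyridin-3-yl)carbonyl on an amine nitrogen in a ring. The amide linkage is thus dropped and an aryl bearing a carboxylic acid is attached directly. Within the data shown here, only one measured step bears on this position, the hydrogen to chloro change from compound 1 to compound 2, and it did not move the number beyond the scatter. It says little about swapping the whole carbonyl-linked heteroaryl for a carboxyphenyl. Among the measured compounds shown here, compound 3 is the only measured example of a non-amide group on this nitrogen, and it sits well above compound 2. A move upward in this assay is therefore expected for compound 4, with wide uncertainty: the expected step is a 4.3-fold higher number from compound 2 to compound 4 (0.63 log units; beyond the scatter), giving an estimate of 600 nM with a range of 200 nM to 2500 nM.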

Compound 4, half-maximal effective concentration: 230 nM
Beside the measured number, compound 4's estimate is 2.6-fold (0.42 log units) above it; the measured number falls inside the stated range.
By their numbers in this assay, from the lowest: compounds 1, 2 and 4 (each within the scatter of the next); then compound 3.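

In this assay, 4-carboxyphenyl in place of (6-chloropyridin-3-yl)carbonyl on the amine nitrogen in the ring gives a 1.6-fold higher number from compound 2 to compound 4 (0.22 log units; within the scatter), and 4-carboxyphenyl in place of (pyridin-3-yl)carbonyl gives a 1.9-fold higher number from compound 1 to compound 4 (0.28 log units; within the scatter). This nitrogen therefore tolerates loss of the carbonyl link with no step beyond the scatter, and a non-amide group here need not give a number like that of compound 3: compound 4 gives 230 nM, whereas compound 3 gives 1200 nM. No measurement on hand accounts for the size of these steps.

Open, from the compounds shown here alone, is whether the carboxylic acid of compound 4 has any bearing on the number, a question that a plain phenyl, a methyl ester or a primary carboxamide on the same nitrogen would address. Also open, going by these compounds, is whether the higher number of compound 3 goes with its sulfonyl link or with its tetrazole, which a sulfonyl-linked 4-carboxyphenyl on that nitrogen would help separate.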